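A few compounds are considered here, and "the series" means these few. Any claim that something is new, unique, unknown or untested is made for them only; others in the source may bear on it.

Compound 1 `C=CCOc1ccc(F)cc1C(=O)c1cccnc1`: > 100000 nM
Compound 2 `C=CCOc1cc(Br)ccc1C(=O)c1cccnc1`: > 100000 nM
Compound 3 `C=CCOc1c(Cl)cccc1C(=O)c1cccnc1`: > 100000 nM

These three compounds were tested in a functional assay on MCF7 cells (Homo sapiens) for cytotoxicity, read by sulforhodamine B assay, with a stated time of 48 h; a lower number here means a stronger inhibitor, a higher number a weaker inhibitor. In this assay compound 3 gives > 100000 nM, which is a limit and not a number. It therefore has no measured potency of its own and stands with the other two compounds at the limit of > 100000 nM in this assay, at which 3 of the 3 values shown sit.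

Compound 4 `O=C(c1cccnc1)c1cccc(Cl)c1O` carries hydrogen in place of allyl on an oxygen on an aromatic ring, an allyloxy to hydroxy change: hydrogen in place of allyl on an oxygen on an aromatic ring. Among the measured compounds shown here, no two measured compounds differ in a single place, so the series offers no measured step to serve as a guide, and the expectation in this assay is correspondingly loose. The expected move, an at least 1.2-fold lower number from compound 3 to compound 4 (0.09 log units; that floor lies within the scatter), is a modest one toward stronger inhibition, and another result reported only as a limit is considered more likely than not. For compound 4 the estimated value is 80000 nM, with an expected range from 25000 nM to 200000 nM.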

Compound 4, half-maximal inhibitory concentration: 26700 nM
For compound 4 the middle estimate is 3.0-fold (0.48 log units) above the measured one, within the range that was stated.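

With hydroxy in place of allyloxy, the series gains its first measured step in this assay, an at least 3.7-fold lower number from compound 3 to compound 4 (0.57 log units; beyond the scatter). Compound 3 is recorded only as a limit, > 100000 nM, so this step is a floor and its full size cannot be read. Losing the allyl group from the oxygen on an aromatic ring is thus the one change shown that brings a compound to a measurable value, and compound 4 alone stands apart from the others: the limit of > 100000 nM in this assay, at which 3 of the 4 values shown sit.

As far as these compounds go, whether the same change would bring compound 1 or compound 2 to a measurable value stays open. So does whether the free hydroxy is needed, or whether a methoxy group or a longer chain on that oxygen would also give a measurable value.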